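Taking one chloro off compound 1

The source may report more compounds than this note shows. Statements on the series, on what has been measured and on what is new or still open speak of the compounds shown alone.

Compound 1 (`O=C(NO)c1ccc(CNC(=O)c2n[nH]cc2NC(=O)c2c(Cl)cccc2Cl)cc1`) gives 10600 nM in a functional assay on NCI-H460 cells (Homo sapiens) for inhibition, read by CCK-8 assay, with a stated time of 72 h (on this read-out lower numbers stand for stronger inhibition and higher numbers for weaker inhibition), and sits level with compound 3 (`Nc1ccccc1NC(=O)c1ccc(CNC(=O)c2n[nH]cc2NC(=O)c2ccccc2F)cc1`) at 9990 nM while compound 2 (`Nc1ccccc1NC(=O)c1ccc(CNC(=O)c2n[nH]cc2NC(=O)c2c(Cl)cccc2Cl)cc1`) reads lower at 4190 nM as a 2.5-fold lower number from compound 1 to compound 2 (0.40 log units; beyond the scatter) shows. That step changes another part of the molecule, so it says little here. Compound 4 (`O=C(NO)c1ccc(CNC(=O)c2n[nH]cc2NC(=O)c2ccccc2Cl)cc1`) carries one change: hydrogen in place of chloro on an aromatic carbon, giving 2-chlorophenyl. The nearest measured change is a 2.4-fold higher number from compound 2 to compound 3 (0.38 log units; beyond the scatter) as 2-fluorophenyl replaces 2,6-dichlorophenyl, though that also brings in fluoro. A smaller move the same way is expected, namely a 1.5-fold higher number from compound 1 to compound 4 (0.18 log units; within the scatter) in this assay for this change. Compound 4 is estimated at 16000 nM with an expected range of 7000 nM to 38000 nM on this read-out.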

Compound 4, half-maximal inhibitory concentration: 6170 nM
Compound 4: middle estimate off by 2.6-fold (0.41 log units), on the high side; measured number below the stated range.
By their numbers in this assay, from the lowest: compounds 2, 4, 3 and 1 (each within the scatter of the next, the first and the last beyond it).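

In this assay, taking one chloro off the 2,6-dichlorophenyl group gives a 1.7-fold lower number from compound 1 to compound 4 (0.24 log units; within the scatter), so on its own this change does not move the reading past the usual scatter. With the hydroxy group kept on the amide nitrogen, the 2-chlorophenyl group therefore reads like the 2,6-dichlorophenyl group, and the second chloro shows no measurable effect here. No measurement at hand explains this result. From the compounds shown here alone, the same removal with the 2-aminophenyl amide of compound 2 remains open. So does what a methyl or methoxy group would do in place of the remaining chloro.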